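The source may hold more compounds than are shown below. What is called first, only, known or untested is meant among the compounds shown, and "the series" means these compounds.

Measured in a functional assay on the whole organism for inhibition, with Rattus norvegicus as the target, read by paw edema, with stated times of 1 h and 3 h; a lower number here means that less compound is needed, a higher number that more compound is needed for the effect:
- Compound 1 `C/C(=N\OCC(N)=O)c1ccc(Cl)cc1`: 24 mg/kg
- Compound 2 `C/C(=N\OCC(N)=O)c1ccc(Br)cc1`: 62 mg/kg
- Compound 3 `C/C(=N\OCC(N)=O)c1ccc(Cl)c(Cl)c1`: 55 mg/kg

In this assay, compound 1 holds the lowest of the three numbers, at 24 mg/kg, so less of it is needed than of either other compound. Compound 4 `C/C(=N\OCC(=O)N(C)C)c1ccc(Cl)cc1` is the next to be read against it. The change is dimethylamino in place of amino on a carbonyl carbon, with dimethylamino in place of amino on a carbonyl carbon.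

Among the compounds with values here, no measured step touches this carbonyl carbon, so the evidence is only indirect. Both measured changes are on an aromatic carbon: a 2.6-fold higher number from compound 1 to compound 2 (0.41 log units; beyond the scatter), and a 2.3-fold higher number from compound 1 to compound 3 (0.36 log units; beyond the scatter). Each was modest and each led away from the low number of compound 1, but two steps elsewhere in the molecule cannot fix this one. A modest rise is therefore expected, held with little confidence. The expected change is a 2.1-fold higher number from compound 1 to compound 4 (0.32 log units; beyond the scatter). Compound 4 is estimated at 50 mg/kg, with an expected range from 18 mg/kg to 140 mg/kg.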

Compound 4, dose for half-maximal effect: 120 mg/kg
Compound 4: the middle estimate sits 2.4-fold (0.38 log units) below what was measured; measured number inside the range.
By their numbers in this assay, from the lowest: compound 1; then compounds 3, 2 and 4 (each within the scatter of the next, the first and the last beyond it).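

At the carbonyl carbon, dimethylamino in place of amino gives a 5.0-fold higher number from compound 1 to compound 4 (0.70 log units; beyond the scatter) in this assay and so moves the number upward. This shows that the response is not confined to changes on the aromatic carbon: this carbonyl position also responds, and the amino group of compound 1 does not tolerate this replacement without more compound being needed. The change removes the hydrogen-bond donor and adds two carbons, but no measurement available here separates these differences or explains the step.

The compounds shown leave open whether a single methyl on the amide nitrogen would give a step of similar size to dimethylamino. They also leave open how a cyclic amine such as pyrrolidine, or a carboxylic acid in place of the amide, would read in this assay at this position.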